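The compounds below may be only part of what the source reports. "The series", "measured", "known", "first", "only" and "open" are said of these compounds alone.

Two compounds of the series share one core with a 4-methoxyphenyl group on each flank and differ only in the group on an aromatic carbon of that core. Within the data shown here, in a functional assay with Oryctolagus cuniculus as the target (a higher number here means a weaker inhibitor, a lower number a stronger inhibitor), compound 2 `COc1ccc(-c2nc(CNC(=O)N3CCOCC3)sc2-c2ccc(OC)cc2)cc1` gives 660 nM, the only number in the set. For compound 1 `COc1ccc(-c2nc(/N=C(\N)NC(C)C)sc2-c2ccc(OC)cc2)cc1` the same assay reports only a limit, > 100 nM. The step that the limit leaves unreadable from compound 1 to compound 2 cannot be read as a size because of the limit of > 100 nM in this assay, at which 1 of the 2 values shown sits. Compound 2 therefore stands alone as the single fixed point.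

Compound 3 `COc1ccc(-c2nc(C(=O)N3CCOCC3)sc2-c2ccc(OC)cc2)cc1` alters the side group once more: (morpholin-4-yl)carbonyl in place of (((morpholin-4-yl)carbonyl)amino)methyl on an aromatic carbon. The (morpholin-4-yl)carbonyl is held directly on the aromatic carbon where compound 2 carries the (((morpholin-4-yl)carbonyl)amino)methyl. Among the measured compounds shown here, no measured step in this assay speaks to a change of this kind, and the one recorded step has no readable size. For compound 3 the expectation in this assay is therefore kept close to the reference with a wide range, estimated at 900 nM, between 250 nM and 4000 nM. The implied step a 1.4-fold higher number from compound 2 to compound 3 (0.13 log units; within the scatter) is expected to stay within the usual scatter.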

Compound 3, half-maximal inhibitory concentration: < 10 nM
Compound 3 was reported as a limit; the forecaster's own chance of this, stated with the estimate: 20%; middle value at least 90-fold (1.95 log units) from the limit.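

Holding the (morpholin-4-yl)carbonyl directly on the aromatic carbon, where the (((morpholin-4-yl)carbonyl)amino)methyl stood, gives in this assay an at least 66-fold lower number from compound 2 to compound 3 (1.81 log units; beyond the scatter), so this position, next to the ring nitrogen and next to the ring sulfur, responds strongly to a change that removes the amino-methyl link while the morpholin-4-yl and carbonyl parts remain. Set against the group of compound 1, the same entering group gives an at least 10-fold lower number from compound 1 to compound 3 (1.00 log units; beyond the scatter), the first step from that compound with a readable lower bound. The value of compound 3 is only a limit, so both steps give the least possible size and not the size itself: the limit of < 10 nM in this assay, at which 1 of the 3 values shown sits.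

The step between the first two compounds still cannot be read, and their order in this assay stays unknown: the limit of > 100 nM in this assay, at which 1 of the 3 values shown sits. The compounds shown also leave open whether the low number needs the morpholin-4-yl group on the carbonyl or only the carbonyl on the aromatic carbon, which a piperidin-1-yl carbonyl, a simple dimethylamino carbonyl or a carboxylic acid at this position would address, as a longer chain between carbonyl and aromatic carbon would for the length of the link.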